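This account rests on a few compounds, and the source may have more. Where it says the series, first, only, none or still open, it means among the compounds named here.

The measured compounds in a functional assay on HepG2 cells (Homo sapiens) for cytotoxicity, read by MTT assay, with a stated time of 48 h; on this read-out lower numbers stand for stronger inhibition and higher numbers for weaker inhibition:

compound 1 `O=C(CSc1nnc(-c2ccncc2)o1)N/N=C/c1cc(Br)ccc1O` — 6490 nM
compound 2 `O=C(CSc1nnc(-c2ccncc2)o1)N/N=C/c1cc(Cl)cc(Cl)c1O` — 3260 nM

The two measured compounds share one core and differ only in the ring attached to the carbon with a double bond to nitrogen. In this assay compound 1 gives 6490 nM and compound 2 gives 3260 nM. Within the data shown here, compound 2 holds the smaller of the two numbers, yet the only step recorded, a 2.0-fold lower number from compound 1 to compound 2 (0.30 log units; within the scatter), lies within the scatter, so the two compounds cannot be told apart on these data.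

Compound 3 `O=C(CSc1nnc(-c2ccncc2)o1)N/N=C/c1cc(Br)cc(Br)c1O` is not yet measured. It differs from compound 2 by 3,5-dibromo-2-hydroxyphenyl in place of 3,5-dichloro-2-hydroxyphenyl on a carbon with a double bond to nitrogen. Among the measured compounds shown here, the one measured step bears on this change only loosely: it swapped a single bromine for two chlorines and moved the number within the scatter. For the measured compounds named here, no measured pair isolates chlorine against bromine at the same positions. On this basis the step from compound 2 to compound 3 is expected to stay within the scatter, an estimated 1.2-fold lower number from compound 2 to compound 3 (0.07 log units; within the scatter). Compound 3 is therefore expected to give about 2800 nM in this assay, with a range from 1200 nM to 7000 nM.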

Compound 3, half-maximal inhibitory concentration: 6540 nM
The estimate for compound 3 lay 2.3-fold (0.37 log units) below the measured number; measured number inside the range.
By their numbers in this assay, from the lowest: compounds 2, 1 and 3 (each within the scatter of the next).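

In this assay the exchange of 3,5-dichloro-2-hydroxyphenyl for 3,5-dibromo-2-hydroxyphenyl on the carbon with a double bond to nitrogen gives a 2.0-fold higher number from compound 2 to compound 3 (0.30 log units; within the scatter) and so shows that, on these data, chlorine and bromine cannot be told apart when both halogens keep the same place in the group's name. The change of bromo in place of hydrogen on an aromatic carbon gives a 1.0-fold higher number from compound 1 to compound 3 (0.00 log units; within the scatter) and so leaves that pair equally inseparable, which means that all three compounds now lie within the scatter of one another and the one-halogen and two-halogen groups shown here give no readable difference. No measurement is available that bears on the reason for these numbers.

The compounds shown leave open whether a group other than a halogen at this position, such as a methoxy group or an amine, would give a step beyond the scatter. They also leave open whether a phenyl ring without the hydroxy group, or a longer chain or a carboxylic acid elsewhere on the shared core, would separate itself from these three compounds.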